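Swapping a benzyloxy group for bromine on a shared core

This account rests on a few compounds, and the source may have more. Where it says the series, first, only, none or still open, it means among the compounds named here.

Of the compounds shown here, three built on one shared core have been tested in a functional assay on MDA-MB-231 cells (Homo sapiens) for cytotoxicity, read by MTT assay, with a stated time of 24 h; on this read-out lower numbers stand for stronger inhibition and higher numbers for weaker inhibition. Compound 1 `Cc1cc(O)c(C(=O)/C=C/c2ccc(Br)cc2)c(-c2ccc(OCc3ccccc3)cc2)c1C(=O)/C=C/c1ccc(Br)cc1` gives 30000 nM, and compound 2 `Cc1cc(O)c(C(=O)/C=C/c2ccc(Cl)cc2)c(-c2ccc(OCc3ccccc3)cc2)c1C(=O)/C=C/c1ccc(Cl)cc1` gives 30000 nM, so the two numbers agree at the digits read. The difference between the core of compound 1 and the core of compound 2 is not broken down here. Compound 3 `Cc1cc(O)c(C(=O)/C=C/c2ccc(Br)cc2)c(-c2ccc(Br)cc2)c1C(=O)/C=C/c1ccc(Br)cc1` differs from compound 1 in one place, (bromo in place of benzyloxy on an aromatic carbon), and in this assay compound 3 gives 18000 nM, a step of a 1.7-fold lower number from compound 1 to compound 3 (0.22 log units; within the scatter).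

Compound 4 `Cc1cc(O)c(C(=O)/C=C/c2ccc(Cl)cc2)c(-c2ccc(Br)cc2)c1C(=O)/C=C/c1ccc(Cl)cc1` is not yet measured. It stands to compound 2 as compound 3 stands to compound 1: the change is bromo in place of benzyloxy on an aromatic carbon, the same change at the same kind of place. The step expected from compound 2 to compound 4 is therefore estimated at a 1.7-fold lower number from compound 2 to compound 4 (0.22 log units; within the scatter), matching in size what was seen from compound 1 to compound 3 because that earlier step was a 1.7-fold lower number from compound 1 to compound 3 (0.22 log units; within the scatter), a shift that sat inside the ordinary spread of repeat tests. On that basis compound 4 is expected to give 18000 nM in this assay, most likely between 9000 nM and 36000 nM.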

Compound 4, half-maximal inhibitory concentration: 15000 nM
Compound 4: middle estimate off by 1.2-fold (0.08 log units), on the high side; the range from low to high includes it.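

In this assay, putting bromo in place of benzyloxy gives a 2.0-fold lower number from compound 2 to compound 4 (0.30 log units; within the scatter). Set beside the earlier step, the swap reads the same on the two cores, as the gap between the two steps is no larger than repeat testing would produce: the same change on two cores in this assay, a 1.7-fold lower number (0.22 log units; within the scatter) from compound 1 to compound 3 and a 2.0-fold lower number (0.30 log units; within the scatter) from compound 2 to compound 4, 1.2-fold (0.08 log units) apart, within the scatter of two such steps What this does not show is that the swap alters the read-out at all: each step on its own lies within the ordinary scatter of repeat tests, and agreement on two cores cannot speak for other cores in the series.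

The compounds shown hold only benzyloxy or bromo at this place on the aromatic ring, which leaves open how a different group there would read, such as an amine, a carboxylic acid or a longer chain. Going by these compounds, all four numbers also come from a single cell assay, and whether the same swap would read alike on other cells or after a different exposure time remains open.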